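The source may report more compounds than this note shows. Statements on the series, on what has been measured and on what is new or still open speak of the compounds shown alone.

Compound 1 `Nc1cc(N)c2nc(-c3ccccc3)c(NCc3ccc(Cl)c(Cl)c3)nc2c1` holds the only number shown here: in a functional assay on K562 cells (Homo sapiens) for inhibition, read by sulforhodamine B assay, with a stated time of 48 h (on this read-out lower numbers stand for stronger inhibition of growth and higher numbers for weaker inhibition of growth), compound 1 gives 17800 nM. Compound 2 `Nc1cc(N)c2nc(-c3ccccc3)c(Oc3ccc(F)cc3)nc2c1` reaches only a limit of the assay, and in this assay compound 2 is reported as < 100000 nM. Compound 3 `Nc1cc(N)c2nc(-c3ccccc3)c(Sc3ccc(Cl)c(Cl)c3)nc2c1` likewise stops at a limit, and in this assay compound 3 gives < 100000 nM. Among the measured compounds shown here, the one measured step, a step that the two limits leave unreadable from compound 2 to compound 3, is unreadable, as the limit of < 100000 nM in this assay, at which 2 of the 3 values shown sit, shows. Compound 4 `COc1ccc(CNc2nc3cc(N)cc(N)c3nc2-c2ccccc2)cc1` differs from compound 1 by 4-methoxyphenyl in place of 3,4-dichlorophenyl on a saturated chain carbon bound to a nitrogen on an aromatic ring. For the measured compounds named here, no measured step touches this exchange, so the expectation rests on compound 1 alone, with a wide range and no direction claimed beyond the scatter. The step of a 1.7-fold higher number from compound 1 to compound 4 (0.23 log units; within the scatter) is therefore estimated as small. Compound 4 is expected to give 30000 nM, within 8000 nM to 100000 nM.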

Compound 4, concentration for total growth inhibition: 97700 nM
Beside the measured number, compound 4's estimate is 3.3-fold (0.51 log units) below it; measured number inside the range.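

Among the compounds shown here, the exchange gives the first readable step at this position: in this assay there is a 5.5-fold higher number from compound 1 to compound 4 (0.74 log units; beyond the scatter). With the chain and the shared core kept, replacing 3,4-dichlorophenyl with 4-methoxyphenyl moves the number beyond the scatter, so the group on this chain does affect the read-out. The compounds shown leave open whether the step follows the loss of the chlorines or the gain of the methoxy, which a plain phenyl or a 4-chlorophenyl on the same chain could separate. Steps involving the other two compounds cannot be read, as their values are limits: the limit of < 100000 nM in this assay, at which 2 of the 4 values shown sit.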